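Furan-amide series: the 5-methyl-1,2-oxazol-3-yl swap

A few compounds are considered here, and "the series" means these few. Any claim that something is new, unique, unknown or untested is made for them only; others in the source may bear on it.

Compound 1 `O=C(CN1C(=O)S/C(=C/c2ccco2)C1=O)Nc1ccc(Cl)c(Cl)c1`: 43300 nM
Compound 2 `O=C(CN1C(=O)S/C(=C/c2ccco2)C1=O)Nc1ccc(Br)cc1`: 94000 nM
Compound 3 `Cc1ccc(NC(=O)CN2C(=O)S/C(=C/c3ccco3)C2=O)cc1`: > 100000 nM (a limit, not a number)

In a functional assay on K562 cells (Homo sapiens) for cytotoxicity, read by propidium iodide staining, with a stated time of 48 h (a higher number here means that more compound is tolerated, a lower number that less compound is tolerated), compound 3 gives only a limit, > 100000 nM. Its true position is therefore open, and any step from it is uncertain.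

Compound 4 `Cc1cc(NC(=O)CN2C(=O)S/C(=C/c3ccco3)C2=O)no1` carries 5-methyl-1,2-oxazol-3-yl in place of 4-methylphenyl on an amide-type nitrogen.

The measured steps that bear on this are changes on the same amide-type nitrogen or on its aromatic group. These are a 2.2-fold higher number from compound 1 to compound 2 (0.34 log units; beyond the scatter) and an at least 2.3-fold higher number from compound 1 to compound 3 (0.36 log units; beyond the scatter), both modest, and an at least 1.0-fold higher number from compound 2 to compound 3 (0.02 log units; that floor lies within the scatter), whose floor lies within the scatter. None of them brings in a five-membered aromatic ring, so the direction stays unsupported.

Given the modest size of an at least 2.3-fold higher number from compound 1 to compound 3 (0.36 log units; beyond the scatter), no step beyond the scatter is expected in this assay, and the estimated change is a number no higher from compound 3 to compound 4 (the limit leaves the size open). Compound 4 is expected at 100000 nM, with an estimated range of 50000 nM to 200000 nM.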

Compound 4, half-maximal cytotoxic concentration: 98600 nM
Compound 4: middle estimate off by 1.0-fold (0.01 log units), on the high side; the range from low to high includes it.
By their numbers in this assay, from the lowest: compound 1; then compounds 2 and 4 (each within the scatter of the next). At a limit, above all of these: compound 3.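

In this assay, 5-methyl-1,2-oxazol-3-yl in place of 4-bromophenyl on the amide-type nitrogen gives a 1.0-fold higher number from compound 2 to compound 4 (0.02 log units; within the scatter), so this five-membered aromatic ring with 2 hetero atoms cannot be told apart from 4-bromophenyl in this assay. Against 3,4-dichlorophenyl, the same change gives a 2.3-fold higher number from compound 1 to compound 4 (0.36 log units; beyond the scatter), which extends the gap seen with the six-membered aromatic groups to a five-membered one and leaves compound 1 alone with the lowest number. Compound 3 has only a limit. The step that remains, an at least 1.0-fold lower number from compound 3 to compound 4 (0.00 log units; that floor lies within the scatter), therefore cannot be read: the limit of > 100000 nM in this assay, at which 1 of the 4 values shown sits.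

From the compounds shown here alone, it remains open whether the methyl on the new ring matters, or whether a ring without it would sit in the same place. Also open, going by these compounds, is how a carboxylic acid or an amine on the aromatic group would behave at this position.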